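Swapping the Urea Aryl Group in a Diaryl Urea Series

The source may hold more compounds than are shown below. What is called first, only, known or untested is meant among the compounds shown, and "the series" means these compounds.

For the measured compounds named here, compound 2 `CN(C)CCn1cnnc1-c1cc(Oc2ccc(NC(=O)Nc3cccc(C(F)(F)F)c3)cc2F)ccn1` gives 1470 nM in a functional assay on HT-29 cells (Homo sapiens) for antiproliferative activity, read by MTT assay, with a stated time of 72 h (a lower number here means a stronger inhibitor, a higher number a weaker inhibitor), the lower of the two numbers measured so far, while compound 1 `Cn1cnnc1-c1cc(Oc2ccc(NC(=O)Nc3cccc(C(F)(F)F)c3)cc2F)ccn1` gives 3020 nM. Going by the values given here, the only measured step, a 2.1-fold lower number from compound 1 to compound 2 (0.31 log units; beyond the scatter), concerns the chain on the aromatic nitrogen. Compound 3 `CN(C)CCn1cnnc1-c1cc(Oc2ccc(NC(=O)Nc3ccc(F)c(F)c3)cc2F)ccn1` differs from compound 2 in one respect: 3,4-difluorophenyl in place of 3-(trifluoromethyl)phenyl on an amide-type nitrogen. Among the compounds with values here, no measured step touches this position, so the data give no direct guide to its size or direction. The expected step in this assay is therefore a 1.4-fold higher number from compound 2 to compound 3 (0.13 log units; within the scatter), close to the scatter. The estimate for compound 3 is 2000 nM, within 700 nM to 6000 nM.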

Compound 3, half-maximal inhibitory concentration: 3620 nM
Beside the measured number, compound 3's estimate is 1.8-fold (0.26 log units) below it, and the stated range covers the measured number.
By their numbers in this assay, from the lowest: compound 2; then compounds 1 and 3 (each within the scatter of the next).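

In this assay, the aryl group on the amide-type nitrogen proves to matter: 3,4-difluorophenyl in place of 3-(trifluoromethyl)phenyl gives a 2.5-fold higher number from compound 2 to compound 3 (0.39 log units; beyond the scatter). For the compounds shown here, the earlier compounds changed only the chain on the aromatic nitrogen, so this is the first reading at this position, and it points toward a weaker inhibitor. Nothing available explains this step.

As far as these compounds go, whether the same swap would give a similar step on the methyl-bearing core of compound 1 remains open. So does how a plain phenyl or a chlorophenyl group would read here.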